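Cytotoxicity notes on a nitroimidazole dithiocarbamate series

The source may hold more compounds than are shown below. What is called first, only, known or untested is meant among the compounds shown, and "the series" means these compounds.

Of the compounds shown here, two have a measured number so far. Compound 1, `Cc1ncc([N+](=O)[O-])n1CCSC(=S)N1CCC(OC(=O)CN2CCCCC2)CC1`, gives 760 ug/mL in an ADME assay on HeLa cells (Homo sapiens) for cytotoxicity; a lower number here means a stronger inhibitor, a higher number a weaker inhibitor. Compound 2, `Cc1ncc([N+](=O)[O-])n1CCSC(=S)N1CCC(O)CC1`, gives 930 ug/mL in this assay. Among the measured compounds shown here, the one step connecting them, a 1.2-fold higher number from compound 1 to compound 2 (0.09 log units; within the scatter), is within the scatter, so the two numbers cannot be ordered against each other. Compound 1 stands at the lowest of the two numbers, with compound 2 its nearest neighbour within the scatter.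

The next compound is compound 3, `Cc1ncc([N+](=O)[O-])n1CCSC(=S)N1CCC(OC(=O)CSC(=S)N2CCCCC2)CC1`. Relative to compound 1 the change is a group of 9 heavy atoms (6 carbon, 1 nitrogen, 2 sulfur; one six-membered non-aromatic ring with 1 hetero atom) in place of a group of 6 heavy atoms (5 carbon, 1 nitrogen; one six-membered non-aromatic ring with 1 hetero atom), on a saturated chain carbon bound to a carbonyl carbon. For the measured compounds named here, no measured step touches this position with this kind of group; the single step from compound 1 to compound 2 concerns the other end of the ester and was within the scatter. Going by the values given here, with nothing among the measured compounds pointing either way, the expectation for compound 3 in this assay is a step of no more than the scatter, a 1.1-fold lower number from compound 1 to compound 3 (0.04 log units; within the scatter), in either direction. Compound 3 is therefore estimated at 700 ug/mL, with an expected range from 350 ug/mL to 1400 ug/mL.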

Compound 3, half-maximal inhibitory concentration: 980 ug/mL
Compound 3: the middle estimate sits 1.4-fold (0.15 log units) below what was measured; measured number inside the range.
By their numbers in this assay, from the lowest: compounds 1, 2 and 3 (each within the scatter of the next).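

In this assay, among the compounds shown here, the step at the saturated chain carbon bound to a carbonyl carbon, where piperidin-1-yl gives way to a group of 9 heavy atoms (6 carbon, 1 nitrogen, 2 sulfur), is a 1.3-fold higher number from compound 1 to compound 3 (0.11 log units; within the scatter) and gives the first reading for this position. The entering group keeps one six-membered non-aromatic ring with 1 hetero atom but adds 1 double bond outside aromatic rings and has 2 hydrogen-bond acceptors rather than 1, and these differences together do not separate compound 3 from compound 1. Neither this change nor the earlier loss of the whole ester side chain, a 1.2-fold higher number from compound 1 to compound 2 (0.09 log units; within the scatter), moves the number beyond the scatter, and no compound shown goes against that reading. No independent measurement bears on this result.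

Still open, going by these compounds, is whether a primary amine, a carboxylic acid or a longer carbon chain on the saturated chain carbon bound to a carbonyl carbon would give a step beyond the scatter. The compounds shown also keep the shared core constant, so they leave open how far a change there would shift the number in this assay.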